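A few compounds are considered here, and "the series" means these few. Any claim that something is new, unique, unknown or untested is made for them only; others in the source may bear on it.

Compound 1 `Cc1oc2c([C@H]3CCN(C)C[C@H]3O)c(O)cc(O)c2c(=O)c1C(O)c1cccc(Cl)c1`: 31%
Compound 2 `CN1CC[C@H](c2c(O)cc(O)c3c(=O)cc(/C=C/c4ccc(Cl)cc4)oc23)[C@H](O)C1`: 12%

In a functional assay on PC-3 cells (Homo sapiens) for inhibition, read by MTT assay, with a stated time of 48 h, tested at 10 uM (a higher number here means more inhibition of growth at the concentration tested, a lower number less inhibition of growth), compound 2 gives 12%, the lower of the two numbers, and compound 1 gives 31%. The gap between these two compounds lies beyond the usual scatter. Compound 3 `CN1CC[C@H](c2c(O)cc(O)c3c(=O)cc(/C=C/c4ccccc4F)oc23)[C@H](O)C1` keeps the core of compound 2 and changes one group: 2-fluorophenyl in place of 4-chlorophenyl on a double-bonded chain carbon bound to a double-bonded chain carbon. Within the data shown here, compound 1 and compound 2 differ in more than one place, so no measured step shows what this swap does. No change beyond the scatter is expected in this assay. The expected result is a number 3 percentage points higher from compound 2 to compound 3 (within the scatter). The estimate for compound 3 is 15%, with an expected range from 3% to 32%.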

Compound 3, percent growth inhibition at one concentration: 25%
For compound 3 the middle estimate is 10 percentage points below the measured one; the range from low to high includes it.
By their numbers in this assay, from the lowest: compound 2; then compounds 3 and 1 (each within the scatter of the next).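

In this assay, 2-fluorophenyl in place of 4-chlorophenyl on a double-bonded chain carbon bound to a double-bonded chain carbon gives a number 13 percentage points higher from compound 2 to compound 3 (beyond the scatter). Among these compounds, this is the first measured step at this position, and it shows that the number responds to a change in this group alone. No measurement shown explains this step. The two groups differ in both their halogen and its numbered place, so 2-chlorophenyl or 4-fluorophenyl would be needed to separate those changes. On these data alone, whether an unsubstituted phenyl would match either compound remains open.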